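Halogen for nitro on the catechol cinnamate ester

The compounds below may be only part of what the source reports. "The series", "measured", "known", "first", "only" and "open" are said of these compounds alone.

Measured compounds and values:
- compound 1 `CC1(C)C2CCC1(C)C(OC(=O)/C=C/c1cc(O)c(O)c(Cl)c1)C2` — 51900 nM
- compound 2 `CC1(C)C2CCC1(C)C(OC(=O)/C=C/c1ccc(O)c(O)c1)C2` — 35900 nM
- compound 3 `O=C(/C=C/c1cc(O)c(O)c([N+](=O)[O-])c1)OCCc1ccccc1` — "not determined" (no result reported)

In a functional assay on BeWo cells (Homo sapiens) for inhibition, read by MTT assay (on this read-out lower numbers stand for stronger inhibition and higher numbers for weaker inhibition), compound 1 gives 51900 nM and compound 2 gives 35900 nM. Compound 3 gives "not determined" (no result reported) in this assay, so its place among the others cannot be stated. Compound 4 `O=C(/C=C/c1cc(O)c(O)c(Br)c1)OCCc1ccccc1` differs from compound 3 by bromo in place of nitro on an aromatic carbon. Within the data shown here, the only measured step that bears on a halogen at this position is a 1.4-fold lower number from compound 1 to compound 2 (0.16 log units; within the scatter), a change too small to read as a trend. Among the measured compounds shown here, no step involving nitro is known. The expectation for compound 4 therefore rests on compounds 1 and 2 alone, with no step beyond the scatter anticipated. Compound 4 is estimated at 40000 nM in this assay, within 10000 nM to 160000 nM.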

Compound 4, half-maximal inhibitory concentration: 8240 nM
For compound 4 the middle estimate is 4.9-fold (0.69 log units) above the measured one; the whole stated range lies above it.
By their numbers in this assay, from the lowest: compound 4; then compounds 2 and 1 (each within the scatter of the next).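

Among these compounds, with no number for compound 3 in this assay, no step to compound 4 at 8240 nM can be read. The compounds shown leave open how bromo compares with nitro on this ester. No evidence bears on this result.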